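Acetyl to propylcarbonyl: an expected half-life for compound 3

The compounds below may be only part of what the source reports. "The series", "measured", "known", "first", "only" and "open" are said of these compounds alone.

Measured so far in an ADME assay on microsomes from liver (Mus musculus) for metabolic stability, read by LC-MS, using NADPH, tested at 1 uM; a lower number here means that the compound disappears faster, a higher number that the compound lasts longer:
Compound 1 `Cc1nc2c(N)ncnc2n1[C@@H]1O[C@H](CN(C)C/C=C\CNC(=O)OC(C)C)[C@@H](O)[C@H]1O` gives > 1.5 h
Compound 2 `CC(=O)NC/C=C\CN(C)C[C@H]1O[C@@H](n2cnc3c(N)ncnc32)[C@H](O)[C@@H]1O` gives > 1.5 h

Compound 2 stands at > 1.5 h, which is a limit of the assay and not a number. Compound 1 gives > 1.5 h, and this too is a limit. Neither compound therefore has an exact half-life, and the record shows (the limit of > 1.5 h in this assay, at which 2 of the 2 values shown sit).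

Compound 3 `CCCC(=O)NC/C=C\CN(C)C[C@H]1O[C@@H](n2cnc3c(N)ncnc32)[C@H](O)[C@@H]1O` differs from compound 2 in one place, with ethyl in place of hydrogen on a saturated chain carbon bound to a carbonyl carbon. Cut one bond further out, the same change reads acetyl to propylcarbonyl. The count of that difference is ethyl in place of hydrogen on a saturated chain carbon bound to a carbonyl carbon.

Going by the values given here, no measured pair of compounds shows this change, so the expectation rests on the structural change alone. In this assay a small step toward faster disappearance is expected, or none beyond the scatter. The expected step is a number no higher from compound 2 to compound 3 (the limit leaves the size open). For compound 3 the estimated half-life is 1.5 h, with an expected range from 0.8 h to 3 h.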

Compound 3, half-life: > 1.5 h
Compound 3 ended at the assay's limit; the forecaster's own chance of this, stated with the estimate: 60%; the middle value lies on the limit itself.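

No step from compound 2 to compound 3 can be read in this assay, because both half-lives are limits of the assay and not numbers: the limit of > 1.5 h in this assay, at which 3 of the 3 values shown sit.

The compounds shown leave open the exact half-lives of compound 1, compound 2 and compound 3, and whether ethyl in place of hydrogen on a saturated chain carbon bound to a carbonyl carbon changes the half-life at all.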